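Phenyl to Pyridin-3-yl on Compound 2

The source may hold more compounds than are shown below. What is called first, only, known or untested is meant among the compounds shown, and "the series" means these compounds.

In a functional assay on HCC827 cells (Homo sapiens) for antiproliferative activity, read by MTT assay, with a stated time of 72 h (on this read-out lower numbers stand for stronger inhibition and higher numbers for weaker inhibition), compound 1 (`CN1CCN(c2ccc(Nc3ncc4nc(SCc5ccccc5)n(C5CCOCC5)c4n3)cc2)CC1`) gives 107 nM and compound 2 (`CN1CCN(c2ccc(Nc3ncc4nc([S+]([O-])Cc5ccccc5)n(C5CCOCC5)c4n3)cc2)CC1`) gives 433 nM as the higher of the two numbers, which means the weaker inhibition of the pair. For the measured compounds named here, the only measured step is a 4.0-fold higher number from compound 1 to compound 2 (0.61 log units; beyond the scatter) and it is modest in size, though beyond the scatter. Compound 3 (`CN1CCN(c2ccc(Nc3ncc4nc([S+]([O-])Cc5cccnc5)n(C5CCOCC5)c4n3)cc2)CC1`) now carries pyridin-3-yl in place of phenyl on a saturated chain carbon bound to a sulfur. Going by the values given here, no measured step covers such a swap. Among the compounds with values here, the one step available keeps the phenyl on both sides, so it offers a rough scale for changes in this side chain but no direction for this one. A step no larger than that one is therefore expected in this assay and most likely one within the scatter, with no firm direction. The step expected is a 1.2-fold higher number from compound 2 to compound 3 (0.06 log units; within the scatter) and it remains an estimate. Compound 3 is estimated at 500 nM with an expected range from 180 nM to 1300 nM once it is measured.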

Compound 3, half-maximal inhibitory concentration: > 10000 nM
Compound 3 ended at the assay's limit; the forecaster's own chance of this, stated with the estimate: 3%; middle value at least 20-fold (1.30 log units) from the limit.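

For the compounds shown here, the exchange of phenyl for pyridin-3-yl on a saturated chain carbon bound to a sulfur brings an at least 23-fold higher number from compound 2 to compound 3 (1.36 log units; beyond the scatter), so this position, seen earlier only with phenyl, proves far more sensitive to a change in the ring itself than the earlier compounds could show. Set beside a 4.0-fold higher number from compound 1 to compound 2 (0.61 log units; beyond the scatter), which kept the phenyl on both sides, an at least 93-fold higher number from compound 1 to compound 3 (1.97 log units; beyond the scatter) is much the larger step, and the swap of one ring carbon for a nitrogen outweighs what was seen before in this side chain. In this assay compound 3 gives > 10000 nM, which is a limit of the assay and not a number: the limit of > 10000 nM in this assay, at which 1 of the 3 values shown sits.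

On these data alone, how far the activity of compound 3 actually falls therefore stays unknown, and the size of the step from compound 2 is only a lower bound. The compounds shown also leave open whether the loss follows the ring nitrogen wherever it sits, as pyridin-4-yl would tell, and whether a ring such as cyclohexyl in place of phenyl would be accepted at this position.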